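This account rests on a few compounds, and the source may have more. Where it says the series, first, only, none or still open, it means among the compounds named here.

Measured so far in an assay on CHO cells for displacement of a labelled ligand from Substance-P receptor (Homo sapiens); on this read-out lower numbers stand for stronger inhibition and higher numbers for weaker inhibition:
- compound 1 `C[C@@H](O[C@H]1CN2C(=O)C=C(c3ccc(CO)cc3)CC2[C@@H]1c1ccc(F)cc1)c1cc(C(F)(F)F)cc(C(F)(F)F)c1`: 0.39 nM
- compound 2 `Cc1cc(C2=CC(=O)N3C[C@H](O[C@H](C)c4cc(C(F)(F)F)cc(C(F)(F)F)c4)[C@@H](c4ccc(F)cc4)C3C2)ccn1`: 0.51 nM
- compound 3 `C[C@@H](O[C@H]1CN2C(=O)C=C(c3cc[nH]c(=O)c3)CC2[C@@H]1c1ccc(F)cc1)c1cc(C(F)(F)F)cc(C(F)(F)F)c1`: 0.27 nM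

Compound 3 gives the lowest of the three numbers in this assay, but its separation from the others is small: a 1.4-fold lower number from compound 1 to compound 3 (0.16 log units; within the scatter) and a 1.9-fold lower number from compound 2 to compound 3 (0.28 log units; within the scatter), both within the scatter. The other measured step, a 1.3-fold higher number from compound 1 to compound 2 (0.12 log units; within the scatter), is likewise within the scatter. All three compounds thus sit together, and no ordering among them can be claimed.

Compound 4 `C[C@@H](O[C@H]1CN2C(=O)C=C(C3CCOCC3)CC2[C@@H]1c1ccc(F)cc1)c1cc(C(F)(F)F)cc(C(F)(F)F)c1` differs from compound 3 by a group of 6 heavy atoms (5 carbon, 1 oxygen; one six-membered non-aromatic ring with 1 hetero atom) in place of a group of 7 heavy atoms (5 carbon, 1 nitrogen, 1 oxygen; one six-membered aromatic ring with 1 hetero atom), on a double-bonded ring carbon. The three measured steps all exchange one six-membered aromatic ring for another at this same position and none moves the number beyond the scatter, so they argue for tolerance of variation at this ring carbon. None of them, however, replaces an aromatic ring by a non-aromatic one or removes a hydrogen-bond donor, so they bear on the step to compound 4 only loosely.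

The expectation is therefore a step of modest size, a 3.0-fold higher number from compound 3 to compound 4 (0.47 log units; beyond the scatter), probably toward a higher number, with wide uncertainty. For compound 4 the number in this assay is estimated at 0.8 nM, with a range from 0.25 nM to 3 nM.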

Compound 4, half-maximal inhibitory concentration: 0.09 nM
Compound 4: middle estimate off by 8.9-fold (0.95 log units), on the high side; measured number outside the range, below it.
By their numbers in this assay, from the lowest: compound 4; then compounds 3, 1 and 2 (each within the scatter of the next).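

In this assay, among these compounds, the double-bonded ring carbon needs neither an aromatic ring nor a hydrogen-bond donor: oxan-4-yl in place of the aromatic ring with one hetero atom gives a 3.0-fold lower number from compound 3 to compound 4 (0.48 log units; beyond the scatter), the first step in this set at this position to lie beyond the scatter. The same group set against 4-(hydroxymethyl)phenyl gives a 4.3-fold lower number from compound 1 to compound 4 (0.64 log units; beyond the scatter), and set against 2-methylpyridin-4-yl it gives a 5.7-fold lower number from compound 2 to compound 4 (0.75 log units; beyond the scatter), so the non-aromatic ring stands apart from all three aromatic groups, which remain within the scatter of one another, and carries the lowest number of the four. No measurement that would explain these steps accompanies the series.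

As far as these compounds go, with a single non-aromatic group in hand, it remains open whether the lower number belongs to saturated rings at this carbon in general or specifically to oxan-4-yl with its ring oxygen. Cyclohexyl would test the ring without the oxygen, piperidin-4-yl would test a ring nitrogen in its place, and an open chain such as 2-methoxyethyl would test whether a ring is needed at all.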